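Methoxy to hydroxy: notes on compound 2 and compound 3

A few compounds are considered here, and "the series" means these few. Any claim that something is new, unique, unknown or untested is made for them only; others in the source may bear on it.

Measured so far:
Compound 1 `CCC[C@H]1OC(=O)/C=C\C=C\[C@H](O)[C@@H](O)[C@@H]1[C@H](C)COC(=O)c1ccc(O)cc1` gives 27500 nM as a number
Compound 2 `CCC[C@@H]1C[C@H](O)[C@@H](OC)/C=C/C=C\C(=O)O1` gives > 100000 nM as a limit

In a functional assay, read by spectrophotometry, with a stated time of 30 min (on this read-out higher numbers stand for an effect only at larger amounts of compound and lower numbers for an effect already at smaller amounts), compound 2 gives > 100000 nM as a limit of the assay and not a number. Compound 3 `CCC[C@@H]1C[C@H](O)[C@@H](O)/C=C/C=C\C(=O)O1` is not yet measured and carries hydrogen in place of methyl on an oxygen on a saturated carbon. Among the measured compounds shown here, no measured pair shows this change, so no shift beyond the scatter is expected in this assay here. The estimated step of a number no higher from compound 2 to compound 3 (the limit leaves the size open) stays that small. For compound 3 the expected value is 100000 nM with an estimated range of 40000 nM to 200000 nM around it.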

Compound 3, half-maximal effective concentration: > 100000 nM
Compound 3: only a limit was reported; the forecaster's own chance of this, stated with the estimate: 65%; the middle value sits exactly at the limit.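

Compound 2 and compound 3 both end at a limit of the assay and not at a number, so no step between them can be read: the limit of > 100000 nM in this assay, at which 2 of the 3 values shown sit.

The compounds shown leave open what effect, if any, the change from methoxy to hydroxy has in this assay.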